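Swapping the furan arm of compound 1 for a dimethylaminoethyl chain

This account rests on a few compounds, and the source may have more. Where it says the series, first, only, none or still open, it means among the compounds named here.

Measured compounds in an assay on HEK293 cells for inhibition of Steryl-sulfatase (Homo sapiens), tested at 1 uM; on this read-out lower numbers stand for a weaker effect and higher numbers for a stronger effect at the one concentration tested:
- compound 1, `NS(=O)(=O)Oc1ccc2c(c1)CN(C(=O)c1ccc(N(Cc3ccccc3)Cc3ccco3)cc1)CC2`, gives 98.2%
- compound 2, `CC(C)CCN(CCC(C)C)c1ccc(C(=O)N2CCc3ccc(OS(N)(=O)=O)cc3C2)cc1`, gives 90.8%
- compound 3, `CCN(Cc1ccc(F)cc1)c1ccc(C(=O)N2CCc3ccc(OS(N)(=O)=O)cc3C2)cc1`, gives 91.2%

All three share the same core and differ only in the two groups carried by the nitrogen on the aromatic ring. Compound 1 gives the largest of the three numbers, but its gap to compound 3 and its gap to compound 2 each lie within the usual scatter, so the three cannot really be told apart on this read-out.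

Compound 4, `CN(C)CCN(Cc1ccccc1)c1ccc(C(=O)N2CCc3ccc(OS(N)(=O)=O)cc3C2)cc1`, has not yet been measured. It differs from compound 1 in one place: (dimethylamino)methyl in place of furan-2-yl on a saturated chain carbon bound to a nitrogen on an aromatic ring.

For the measured compounds named here, only one measured step speaks to this kind of change. It also alters the groups on that same aromatic nitrogen, and it was a number 0.4 percentage points higher from compound 2 to compound 3 (within the scatter). With that single comparison showing no movement beyond the scatter, and with all three measured numbers crowded near the top of the scale, the expectation for compound 4 is a number close to that of compound 1, with no step beyond the scatter in either direction; the expected step is a number 5.2 percentage points lower from compound 1 to compound 4 (within the scatter). The estimate for compound 4 in this assay is therefore 93%, with a range from 84% to 99%.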

Compound 4, a percentage reported as inhibition, at one concentration (the size of the read-out at that concentration, not a potency): 57.8%
The estimate for compound 4 lay 35.2 percentage points above the measured number; the whole stated range lies above it.
By their numbers in this assay, from the lowest: compound 4; then compounds 2, 3 and 1 (each within the scatter of the next).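

In this assay, the groups on the aromatic nitrogen are not freely interchangeable: a number 40.4 percentage points lower from compound 1 to compound 4 (beyond the scatter), even though the other group on that nitrogen and the shared core stay the same. The earlier compounds offered only a step that stayed within the scatter, a number 0.4 percentage points higher from compound 2 to compound 3 (within the scatter), whereas the change from (furan-2-yl)methyl to 2-(dimethylamino)ethyl is the only step shown that goes beyond it, so this position can strongly affect the read-out. No available measurement explains why this swap lowers the number.

The compounds shown cannot separate the loss of the furan ring from the arrival of the dimethylamino group, and a plain propyl chain or a 2-methoxyethyl chain in that place would help to pull those two apart. They also leave open whether a 3-(dimethylamino)propyl chain, or a thiophene ring in place of the furan ring, would give a number closer to that of compound 1.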